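Replacing thiophen-3-yl with 1-methyl-1H-pyrazol-5-yl on a carbonyl carbon

A few compounds are considered here, and "the series" means these few. Any claim that something is new, unique, unknown or untested is made for them only; others in the source may bear on it.

Values measured in a functional assay on SK-OV-3 cells (Homo sapiens) for inhibition, read by colorimetric assay and sulforhodamine B assay, with a stated time of 48 h (on this read-out lower numbers stand for stronger inhibition of growth and higher numbers for weaker inhibition of growth), are these:
Compound 1 `CCCCCCCCCCCC[C@@H](O)[C@H]1CC[C@H]([C@H](O)CCCCCCCCCCNC(=O)c2cccs2)O1` gives 28800 nM
Compound 2 `CCCCCCCCCCCC[C@@H](O)[C@H]1CC[C@H]([C@H](O)CCCCCCCCCCNC(=O)c2ccsc2)O1` gives 100000 nM

Among the measured compounds shown here, compound 2 holds the higher number of the two, and compound 1 is its only measured neighbour. Compound 3 `CCCCCCCCCCCC[C@@H](O)[C@H]1CC[C@H]([C@H](O)CCCCCCCCCCNC(=O)c2ccnn2C)O1` has not yet been measured. It carries 1-methyl-1H-pyrazol-5-yl in place of thiophen-3-yl on a carbonyl carbon. For the measured compounds named here, the one measured step that bears on this change is a 3.5-fold higher number from compound 1 to compound 2 (0.54 log units; beyond the scatter) for thiophen-3-yl in place of thiophen-2-yl at that same place. This single step is thin evidence, but it suggests that a modest move is plausible. Going by the values given here, with compound 2 at 100000 nM as the high end of the numbers so far, a move toward a lower number seems more likely. The expected change is a 2.2-fold lower number from compound 2 to compound 3 (0.35 log units; beyond the scatter) and this remains an uncertain estimate. In this assay compound 3 is estimated at 45000 nM with 13000 nM as the expected lower end and 130000 nM as the upper end.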

Compound 3, concentration for 50% growth inhibition: 100000 nM
Estimate against measurement, compound 3: 2.2-fold (0.35 log units) below; the range from low to high includes it.
By their numbers in this assay, from the lowest: compound 1; then compounds 2 and 3 (each within the scatter of the next).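

In this assay the exchange of thiophen-3-yl for 1-methyl-1H-pyrazol-5-yl shows no change at the digits printed from compound 2 to compound 3 (within the scatter) on this carbonyl carbon, so a second hetero atom in the ring and a sixth heavy atom in the group left the reading where it stood. Set against thiophen-2-yl, the same group gives a 3.5-fold higher number from compound 1 to compound 3 (0.54 log units; beyond the scatter) and matches in size the earlier 3.5-fold higher number from compound 1 to compound 2 (0.54 log units; beyond the scatter) so that compound 1 now stands apart from two different groups rather than one. The data offer no measured explanation of why thiophen-2-yl differs from the other two groups.

Going by these compounds, it remains open whether a furan-2-yl or phenyl ring on this carbonyl carbon would read with compound 1 or with compound 2 and compound 3. Also open, on these data alone, is how a shorter chain leading to the amide nitrogen would alter these numbers.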